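The source may hold more compounds than are shown below. What is called first, only, known or untested is meant among the compounds shown, and "the series" means these compounds.

Measured compounds:
compound 1, `COc1ccc2[nH]c(-c3nc(C)no3)cc2c1` – 16700 nM
compound 2, `COc1ccc2[nH]c(-c3nc(-c4ccccc4)no3)cc2c1` – > 50000 nM
compound 3, `Clc1ccc(-c2noc(-c3cc4ccccc4[nH]3)n2)cc1` – > 50000 nM

In a functional assay on MCF7 cells (Homo sapiens) for antiproliferative activity, read by WST assay, with a stated time of 72 h (a lower number here means a stronger inhibitor, a higher number a weaker inhibitor), compound 1 gives 16700 nM. The value of compound 2 is a limit of the assay, > 50000 nM. The value of compound 3 is likewise a limit, > 50000 nM. For the measured compounds named here, the one step that can be sized, an at least 2.9-fold higher number from compound 1 to compound 2 (0.47 log units; beyond the scatter), shows that replacing methyl with phenyl on the shared core weakens inhibition. Compound 3 therefore stands only at a bound, not at a number; it is one of the compounds sitting at the limit of > 50000 nM in this assay, at which 2 of the 3 values shown sit.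

Compound 4, `COc1ccc2[nH]c(-c3nc(-c4ccc(Cl)cc4)no3)cc2c1`, differs from compound 3 by methoxy in place of hydrogen on an aromatic carbon. Going by the values given here, no measured step concerns this change, so the expectation rests on the neighbouring values: compound 2, which carries the same methoxy and a phenyl ring, sits at its limit, and compound 3 sits at its limit. Compound 4 is therefore expected to give 60000 nM, between 20000 nM and 200000 nM, most likely again reported only as a limit. The step that the limit leaves unreadable from compound 3 to compound 4 is estimated to be none beyond the scatter, so that compound 4 is expected to remain a very weak inhibitor.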

Compound 4, half-maximal inhibitory concentration: > 50000 nM
Compound 4 gave a limit, no number (the forecaster's own chance of this, stated with the estimate: 75%); the middle value does not contradict the limit.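

In this assay compound 4 stands at a limit, the same one as compound 2 and compound 3: the limit of > 50000 nM in this assay, at which 3 of the 4 values shown sit. The steps to compound 4 from compound 3, which adds methoxy on the aromatic carbon of the shared core, and from compound 2, which adds chloro to the phenyl ring, cannot be read, so neither change is shown to bring back a measurable value. For the compounds shown here, what is new is that the loss seen with phenyl in place of methyl also holds with 4-chlorophenyl, which gives an at least 2.9-fold higher number from compound 1 to compound 4 (0.47 log units; beyond the scatter), and compound 1, with its methyl, remains the only compound of the four with a number.

Going by these compounds alone, what methoxy itself contributes remains open, as the one pair that differs by this group sits entirely at the limit, and its effect in the presence of methyl cannot be judged from these compounds. Also open, from the compounds shown here alone, is whether an amine, a carboxylic acid or a short chain such as ethyl in place of methyl would give a stronger inhibitor than compound 1 or a weaker one.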